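Hydroxy removal across the shared core: estimating compound 4

The source may report more compounds than this note shows. Statements on the series, on what has been measured and on what is new or still open speak of the compounds shown alone.

Measured compounds:
Compound 1 `O=c1cc(/C=C/c2ccc(O)c(O)c2)oc2cc(O)cc(O)c12` gives 260 nM in a functional assay, in the absence of a further agent; on this read-out higher numbers stand for weaker inhibition and lower numbers for stronger inhibition.
Compound 2 `O=c1cc(/C=C/c2ccc(O)c(O)c2)oc2cc(O)ccc12` gives 300 nM in this assay.
Compound 3 `O=c1cc(/C=C/c2ccc(O)c(O)c2)oc2cccc(O)c12` gives 260 nM in this assay.

Compound 1 sits level with compound 3 at the digits shown, the two together the lowest of the three numbers; compound 2 is nearest otherwise, with a 1.2-fold higher number from compound 1 to compound 2 (0.06 log units; within the scatter), and no change at the digits printed from compound 1 to compound 3 (within the scatter). Both hydroxy removals so far stayed within the scatter.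

Compound 4 `O=c1cc(/C=C/c2ccc(O)cc2)oc2cc(O)cc(O)c12` takes the change (hydrogen in place of hydroxy on an aromatic carbon), here on an aromatic carbon of a six-membered aromatic ring of carbon only, ortho to a hydroxy group and meta to a large group. Within the data shown here, no measured step touches this place; the two that bear on hydroxy loss elsewhere were flat. Compound 4 is therefore expected to show a 1.3-fold higher number from compound 1 to compound 4 (0.13 log units; within the scatter) in this assay, no move beyond the scatter. The estimate for compound 4 is 350 nM, from 150 nM to 900 nM.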

Compound 4, half-maximal inhibitory concentration: 1250 nM
Beside the measured number, compound 4's estimate is 3.6-fold (0.55 log units) below it; the whole stated range lies below it.
By their numbers in this assay, from the lowest: compounds 1, 3 and 2 (each within the scatter of the next); then compound 4.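

In this assay, hydrogen in place of hydroxy, ortho to a hydroxy group and meta to a large group, gives a 4.8-fold higher number from compound 1 to compound 4 (0.68 log units; beyond the scatter) and so lies beyond the scatter, unlike the two earlier removals in compound 2 and compound 3. Hydroxy loss from the shared core is therefore not flat at every place, and the result depends on where the loss falls. Nothing shown accounts for this step.

Going by these compounds, whether a methoxy group or an amine at this place would track compound 1 or compound 4 remains open. So does the effect of removing the remaining hydroxy group on that ring.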